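Capping a Phenol Oxygen: From Compound 1 to Compound 3

The source may report more compounds than this note shows. Statements on the series, on what has been measured and on what is new or still open speak of the compounds shown alone.

Compound 1 `O=C(Nc1cccc(-n2cc(-c3ccncc3)c(-c3cc(O)cc(Cl)c3)n2)c1)Nc1ccc(Cl)c(C(F)(F)F)c1` — 99%
Compound 2 `O=C(Nc1cccc(-n2cc(-c3ccncc3)c(-c3cc(O)cc(Cl)c3)n2)c1)Nc1ccc(Cl)c(Cl)c1` — 101%

In a functional assay on COLO 205 cells (Homo sapiens) for inhibition, read by sulforhodamine B assay, with a stated time of 48 h, tested at 1 uM (on this read-out higher numbers stand for a weaker effect at the one concentration tested and lower numbers for a stronger effect), compound 1 gives 99%, and compound 2 gives 101%. On these numbers compound 1 stands alongside compound 2, since a number 2 percentage points higher from compound 1 to compound 2 (within the scatter) lies within the scatter. Compound 3 `COc1cc(Cl)cc(-c2nn(-c3cccc(NC(=O)Nc4ccc(Cl)c(C(F)(F)F)c4)c3)cc2-c2ccncc2)c1` differs from compound 1 by methyl in place of hydrogen on an oxygen on an aromatic ring. For the measured compounds named here, no measured step touches this place; the single step known, chloro in place of trifluoromethyl on an aromatic carbon, sits elsewhere and was within the scatter. Compound 3 is therefore expected to show no step beyond the scatter, a number 1 percentage points lower from compound 1 to compound 3 (within the scatter). Compound 3 is estimated at 98%, between 85% and 106%.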

Compound 3, a percentage reported as activity, at one concentration (the size of the read-out at that concentration, not a potency): 80%
Estimate against measurement, compound 3: 18 percentage points above; measured number outside the range, below it.
By their numbers in this assay, from the lowest: compound 3; then compounds 1 and 2 (each within the scatter of the next).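

Unlike chloro in place of trifluoromethyl, hydroxy to methoxy on the 3-chloro-5-hydroxyphenyl group moves the number in this assay beyond the scatter: methyl in place of hydrogen on this oxygen gives a number 19 percentage points lower from compound 1 to compound 3 (beyond the scatter) as a modest step towards a stronger effect. This oxygen is therefore a place where a single added carbon registers in this read-out. Nothing measured here accounts for the step.

Open, as far as these compounds go, is whether a longer chain on this oxygen, such as ethyl, or an amine in place of the hydroxy would shift the number further. Also open, from the compounds shown here alone, is whether the same methyl would act alike on compound 2.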